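Acid ceramidase series: pyridyl in place of fluorophenyl

The source may hold more compounds than are shown below. What is called first, only, known or untested is meant among the compounds shown, and "the series" means these compounds.

Of the compounds shown here, three on the shared core have been measured in an assay on isolated protein for inhibition of acid ceramidase (Homo sapiens), read by LC-MS, with a stated time of 1 h; a higher number here means a weaker inhibitor, a lower number a stronger inhibitor. Compound 1 `Cc1oc(=O)n(C(=O)NCCCCc2ccccc2)c1-c1ccccc1` gives 42 nM. Compound 2 `O=C(NCCCCc1ccccc1)n1c(-c2ccc(Cl)cc2)coc1=O` gives 5 nM. Compound 3 `O=C(NCCCCc1ccccc1)n1cc(-c2ccc(F)cc2)oc1=O` gives 185 nM, the highest of the three numbers; its gap to compound 1 and its gap to compound 2 both lie beyond the scatter, so on these numbers compound 3 is the weakest inhibitor of the three.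

Compound 4 `O=C(NCCCCc1ccccc1)n1cc(-c2ccncc2)oc1=O` is the next compound to be measured. Relative to compound 3 the change is pyridin-4-yl in place of 4-fluorophenyl on an aromatic carbon. Among the compounds with values here, no measured pair differs only in this way, and compounds 1 and 2 differ from compound 3 in more than one place, so they give no direct guide to the size of this step. Within the data shown here, with no precedent, the step is expected to be small, at most a modest weakening, and may well fall within the scatter of repeated measurements.

Compound 4 is therefore expected to give about 300 nM in this assay, with a range from 100 nM to 900 nM. This corresponds to an expected 1.6-fold higher number from compound 3 to compound 4 (0.21 log units; within the scatter).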

Compound 4, half-maximal inhibitory concentration: 18 nM
Beside the measured number, compound 4's estimate is 17-fold (1.22 log units) above it; the measured number lies below the stated range.
By their numbers in this assay, from the lowest: compound 2; then compound 4; then compound 1; then compound 3.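

In this assay, within the data shown here, the exchange of 4-fluorophenyl for pyridin-4-yl is a 10-fold lower number from compound 3 to compound 4 (1.01 log units; beyond the scatter), the first single-place comparison. It shows that this aromatic carbon, next to the ring oxygen, is sensitive to the identity of the attached six-membered aromatic ring: a ring of carbon only carrying fluorine and a ring with one hetero atom are far from equivalent here, and the pyridin-4-yl compound is the stronger inhibitor. Nothing available explains why this exchange has so large an effect.

The step changes two things at once, the fluorine leaving and the ring nitrogen entering, so their shares remain unseparated; an unsubstituted phenyl at this carbon, together with pyridin-3-yl or pyridin-2-yl, would divide them and test where the ring nitrogen needs to sit. Also open, as far as these compounds go, is whether the same exchange would have a similar effect on the arrangement of compound 2, or with a pyrimidine ring or an amine-bearing phenyl at this carbon.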